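A few compounds are considered here, and "the series" means these few. Any claim that something is new, unique, unknown or untested is made for them only; others in the source may bear on it.

Measured so far:
compound 1, `CN(CC(N)=O)C[C@@H]1CCCc2cc(S(=O)(=O)c3cccc(F)c3)ccc21`: 1.26 nM
compound 2, `CNCC(=O)NC[C@@H]1CCCc2cc(S(=O)(=O)c3cccc(F)c3)ccc21`: 0.159 nM

In an assay on isolated protein for displacement of a labelled ligand from 5-hydroxytryptamine receptor 6 (Homo sapiens) (on this read-out lower numbers stand for stronger inhibition and higher numbers for weaker inhibition), compound 2 gives the lowest of the two numbers; its nearest neighbour is compound 1, whose number lies higher by a 7.9-fold lower number from compound 1 to compound 2 (0.90 log units; beyond the scatter). Compound 3, `CN(C[C@@H]1CCCc2cc(S(=O)(=O)c3cccc(F)c3)ccc21)S(C)(=O)=O`, has not yet been tested. It differs from compound 2 in one place: methyl(methylsulfonyl)amino in place of (((methylamino)methyl)carbonyl)amino on a saturated chain carbon bound to a saturated ring carbon. Going by the values given here, the single step available, from compound 1 to compound 2, swaps one chain end for another and moved the number in this assay by a 7.9-fold lower number from compound 1 to compound 2 (0.90 log units; beyond the scatter). That step kept a nitrogen bearing a hydrogen and a methyl group; the change to compound 3 removes both hydrogen-bond donors, a larger departure than the measured step covers. Compound 3 is therefore expected to give a higher number than compound 2, with a step of a 31-fold higher number from compound 2 to compound 3 (1.50 log units; beyond the scatter) that should exceed the scatter. The estimate for compound 3 is 5 nM, within a range from 1 nM to 30 nM.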

Compound 3, inhibition constant: 0.398 nM
Estimate against measurement, compound 3: 13-fold (1.10 log units) above, outside the stated range (below it).
By their numbers in this assay, from the lowest: compound 2; then compound 3; then compound 1.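

Swapping the (((methylamino)methyl)carbonyl)amino group for methyl(methylsulfonyl)amino in this assay gives a 2.5-fold higher number from compound 2 to compound 3 (0.40 log units; beyond the scatter) and is a real but modest loss. The incoming group has 0 hydrogen-bond donors where the outgoing group has 2, so in this set of compounds, a value as low as that of compound 3 at 0.398 nM on this saturated chain carbon does not depend on those donors. On the amine nitrogen, methylsulfonyl in place of carbamoylmethyl gives a 3.2-fold lower number from compound 1 to compound 3 (0.50 log units; beyond the scatter) and places compound 3 between the other two.

Still open, as far as these compounds go, is how a plain acetyl group or a larger phenylsulfonyl group on that nitrogen would compare. No measurement shown here explains either shift.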